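The source may report more compounds than this note shows. Statements on the series, on what has been measured and on what is new or still open speak of the compounds shown alone.

In a functional assay on HepG2 cells (Homo sapiens) for inhibition, read by MTT assay, with a stated time of 24 h (on this read-out lower numbers stand for stronger inhibition of growth and higher numbers for weaker inhibition of growth), the compounds measured so far are these

compound 1 `COc1cc(C(=O)n2c(-c3cn(C)c4ccccc34)nc3ccccc32)cc(OC)c1OC` gives 4300 nM
compound 2 `COc1ccc2c(c1)c(-c1nc3ccccc3n1C(=O)c1cc(OC)c(OC)c(OC)c1)cn2C` gives 3800 nM
compound 3 `COc1ccc(C(=O)n2c(-c3cn(C)c4ccc(Br)cc34)nc3ccccc32)cc1OC` gives 9700 nM

Of these three, compound 3 has the highest number and so the weakest growth inhibition. Compound 4 `COc1cc(C(=O)n2c(-c3cn(C)c4ccc(Br)cc34)nc3ccccc32)cc(OC)c1OC` differs from compound 3 by one change (methoxy in place of hydrogen on an aromatic carbon), methoxy in place of hydrogen on an aromatic carbon, ortho to a methoxy group. One measured step carries the same description (a 1.1-fold lower number from compound 1 to compound 2 (0.05 log units; within the scatter)) and lies within the scatter, but there the methoxy enters at another place in the molecule. Compound 1 and compound 2 both share with compound 4 the three methoxy groups that this change completes, and both stand lower than compound 3, yet each differs from compound 3 in more than one place. That is weak support for a small fall in this assay, within the scatter or little beyond it. The expected change is a 1.5-fold lower number from compound 3 to compound 4 (0.17 log units; within the scatter) and no more. For compound 4 the estimated value is 6500 nM, with an expected range from 3000 nM to 13000 nM in this read-out.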

Compound 4, concentration for 50% growth inhibition: 8200 nM
Beside the measured number, compound 4's estimate is 1.3-fold (0.10 log units) below it, within the range that was stated.
By their numbers in this assay, from the lowest: compounds 2, 1, 4 and 3 (each within the scatter of the next, the first and the last beyond it).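

In this assay, the methoxy that enters ortho to a methoxy group, completing the three methoxy groups of compound 4, makes no readable difference, with a 1.2-fold lower number from compound 3 to compound 4 (0.07 log units; within the scatter). Within the data shown here, the swaps at the other place of change give a first reading of the bromo group there: bromo in place of methoxy gives a 2.2-fold higher number from compound 2 to compound 4 (0.33 log units; beyond the scatter), a modest step, while bromo in place of hydrogen gives a 1.9-fold higher number from compound 1 to compound 4 (0.28 log units; within the scatter). The methoxy change thus reads alike at two different places on two cores, which the single earlier step could not show: the same change on two cores in this assay, a 1.1-fold lower number (0.05 log units; within the scatter) from compound 1 to compound 2 and a 1.2-fold lower number (0.07 log units; within the scatter) from compound 3 to compound 4, 1.0-fold (0.02 log units) apart, within the scatter of two such steps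

With only hydrogen and methoxy shown at this position, what a hydroxyl group, an amine or a longer chain such as ethoxy would do there stays open. From the compounds shown here alone, whether any group at this position can move the number beyond the scatter also remains open.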